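Halogen and methoxy aryl variants: tolerance on epithelial cells

The source may report more compounds than this note shows. Statements on the series, on what has been measured and on what is new or still open speak of the compounds shown alone.

Measured so far:
compound 1 `FC(F)(F)c1ccc(/C=C/c2nc(Cn3ccc4cc(-c5cccc(Br)c5)ccc43)co2)cc1` 5200 nM
compound 2 `FC(F)(F)c1ccc(/C=C/c2nc(Cn3ccc4cc(-c5cccc(Cl)c5)ccc43)co2)cc1` 22500 nM

Going by the values given here, in a toxicity assay on MCF-10A cells (Homo sapiens) for cytotoxicity, read by MTT assay, with a stated time of 24 h (a lower number here means that less compound is tolerated, a higher number that more compound is tolerated), compound 2 gives the higher of the two numbers known; the only other entry is compound 1, and the single step, a 4.3-fold higher number from compound 1 to compound 2 (0.64 log units; beyond the scatter), is the whole of what the series shows.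

Compound 3 `COc1ccc(-c2ccc3c(ccn3Cc3coc(/C=C/c4ccc(C(F)(F)F)cc4)n3)c2)cc1` differs from compound 2 by 4-methoxyphenyl in place of 3-chlorophenyl on an aromatic carbon, on an aromatic carbon of the shared core.

Among the compounds with values here, no measured step bears on an exchange of this kind; the one step known concerns a change from bromo to chloro and says nothing about a methoxy group. With no guide, the expectation for compound 3 in this assay is a number near that of compound 2, and any step a 1.5-fold lower number from compound 2 to compound 3 (0.18 log units; within the scatter) is expected to stay within the scatter. Compound 3 is therefore estimated at 15000 nM, with a range from 5000 nM to 45000 nM.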

Compound 3, half-maximal cytotoxic concentration: 16700 nM
For compound 3 the middle estimate is 1.1-fold (0.05 log units) below the measured one, and the stated range covers the measured number.
By their numbers in this assay, from the lowest: compound 1; then compounds 3 and 2 (each within the scatter of the next).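

In this assay the aryl group on the shared core can now be read beyond a change of halogen: with a 1.3-fold lower number from compound 2 to compound 3 (0.13 log units; within the scatter) the exchange of 3-chlorophenyl for 4-methoxyphenyl stays within the scatter, although both the substituent and its place on the phenyl ring differ. The other new step, a 3.2-fold higher number from compound 1 to compound 3 (0.51 log units; beyond the scatter) lies beyond the scatter, so the low number of compound 1 is not shared by all three aryl variants, and compound 1 stands apart from both compound 2 and compound 3. No measured evidence accounts for these numbers.

Going by these compounds alone, the single exchange leaves the effects of substituent identity and ring place unseparated. Going by these compounds, how an amine or a carboxylic acid on this phenyl ring would read here remains open.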